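Predicting cytotoxicity after swapping a pyridinyl for a bromofluorophenyl

This account rests on a few compounds, and the source may have more. Where it says the series, first, only, none or still open, it means among the compounds named here.

Measured compounds:
- compound 1 `N#Cc1ccc(Nc2nccc(OCc3cccnc3)n2)cc1`: 6400 nM
- compound 2 `N#Cc1ccc(Nc2nccc(OCc3ccc(Br)cc3)n2)cc1`: 16000 nM
- compound 3 `COc1ccc(COc2ccnc(Nc3ccc(C#N)cc3)n2)cc1`: 102000 nM

All three compounds share the same core and differ only in the aromatic group on the saturated chain carbon bound to an oxygen on an aromatic ring. In an ADME assay on MT4 cells (Homo sapiens) for cytotoxicity, read by MTT assay, with a stated time of 5 days (on this read-out higher numbers stand for lower toxicity in this test and lower numbers for higher toxicity in this test), compound 1 stands lowest of the three numbers, meaning it is the most toxic of them here; the nearest is compound 2, as shown by a 2.5-fold higher number from compound 1 to compound 2 (0.40 log units; beyond the scatter), and the furthest is compound 3, as shown by a 16-fold higher number from compound 1 to compound 3 (1.20 log units; beyond the scatter).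

Compound 4 `N#Cc1ccc(Nc2nccc(OCc3ccc(Br)cc3F)n2)cc1` is not yet measured. Its change from compound 1 is 4-bromo-2-fluorophenyl in place of pyridin-3-yl on a saturated chain carbon bound to an oxygen on an aromatic ring.

Going by the values given here, the step that bears most directly on this change is the one from compound 1 to compound 2, where a 4-bromophenyl replaced the same pyridin-3-yl and gave a 2.5-fold higher number from compound 1 to compound 2 (0.40 log units; beyond the scatter). Compound 4 carries that same 4-bromophenyl pattern with an added fluorine, so a modest rise in this assay is expected, close to what compound 2 showed. The step from compound 2 to compound 3, a 6.4-fold higher number from compound 2 to compound 3 (0.80 log units; beyond the scatter), involves a methoxy and does not bear directly on a fluorine.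

Compound 4 is therefore estimated at 15000 nM, within a range of 5000 nM to 45000 nM, which is expected to mean a 2.3-fold higher number from compound 1 to compound 4 (0.37 log units; beyond the scatter).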

Compound 4, half-maximal cytotoxic concentration: 141000 nM
For compound 4 the middle estimate is 9.4-fold (0.97 log units) below the measured one; the whole stated range lies below it.
By their numbers in this assay, from the lowest: compound 1; then compound 2; then compounds 3 and 4 (each within the scatter of the next).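

In this assay, going by these compounds alone, a single fluoro in place of hydrogen on an aromatic carbon of the 4-bromophenyl group gives an 8.8-fold higher number from compound 2 to compound 4 (0.95 log units; beyond the scatter), so one small atom swap at this place can shift the number considerably, which the earlier compounds could not reveal. The full change, 4-bromo-2-fluorophenyl in place of pyridin-3-yl, gives a 22-fold higher number from compound 1 to compound 4 (1.34 log units; beyond the scatter), and the other comparison, a 1.4-fold higher number from compound 3 to compound 4 (0.14 log units; within the scatter), lies within the scatter, so these two compounds cannot be told apart in this assay. Within the data shown here, two differently substituted phenyl groups thus reach the same level of this read-out, and no measurement here explains why the fluoro shifts the number so far.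

The compounds shown leave open whether fluoro would do the same on a phenyl without the bromo, or on the 4-methoxyphenyl group of compound 3. Also open, going by these compounds, is how a chloro or a trifluoromethyl in place of that fluoro, or a longer chain in place of the saturated chain carbon, would read in this assay.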